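Bromo for methoxy at a second position: growth inhibition notes

A few compounds are considered here, and "the series" means these few. Any claim that something is new, unique, unknown or untested is made for them only; others in the source may bear on it.

Measured compounds, with their values in a functional assay on A549 cells (Homo sapiens) for inhibition, read by MTT assay, with a stated time of 24 h; a lower number here means a stronger inhibitor of growth, a higher number a weaker inhibitor of growth:
compound 1 `COc1ccccc1C(=O)n1c(-c2cn(C)c3ccccc23)nc2ccccc21`: 12300 nM
compound 2 `Cn1cc(-c2nc3ccccc3n2C(=O)c2ccccc2Br)c2ccccc21`: 43200 nM
compound 3 `COc1ccc2c(c1)c(-c1nc3ccccc3n1C(=O)c1ccccc1)cn2C`: 16700 nM

Among the measured compounds shown here, the one counted step runs from compound 1 to compound 2, (bromo in place of methoxy on an aromatic carbon), and gives a 3.5-fold higher number from compound 1 to compound 2 (0.55 log units; beyond the scatter). Compound 1 and compound 3 share the same atoms joined differently; the difference between the two cores is not broken down here, and their values in this assay lie within the usual scatter of each other, so nothing is read from that pair.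

Compound 4 `Cn1cc(-c2nc3ccccc3n2C(=O)c2ccccc2)c2cc(Br)ccc21` is not yet measured. It differs from compound 3 by bromo in place of methoxy on an aromatic carbon. For the measured compounds named here, this is the same kind of change as the one from compound 1 to compound 2, but not the same: there the bromo sits on a six-membered aromatic ring of carbon only, ortho to a large group; here it sits on a ring that is part of a fused or bridged system of two rings, meta to a fused ring and para to a fused ring.

For compound 4 in this assay a step of a 2.1-fold higher number from compound 3 to compound 4 (0.32 log units; beyond the scatter) is expected, beside a 3.5-fold higher number from compound 1 to compound 2 (0.55 log units; beyond the scatter), resting on that single measured step at a different place. The estimate for compound 4 is 35000 nM, in the range 12000 nM to 100000 nM.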

Compound 4, concentration for 50% growth inhibition: 23100 nM
Compound 4: middle estimate off by 1.5-fold (0.18 log units), on the high side, and the stated range covers the measured number.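

In this assay, bromo in place of methoxy on an aromatic carbon of the ring that is part of a fused or bridged system of two rings gives a 1.4-fold higher number from compound 3 to compound 4 (0.14 log units; within the scatter), so on this core the change cannot be told apart from the usual scatter of repeated measurements. Set beside the earlier step on the core of compound 1, the two steps do not differ beyond what two such steps can scatter: the same change on two cores in this assay, a 3.5-fold higher number (0.55 log units; beyond the scatter) from compound 1 to compound 2 and a 1.4-fold higher number (0.14 log units; within the scatter) from compound 3 to compound 4, 2.5-fold (0.40 log units) apart, within the scatter of two such steps. This shows no measurable dependence on the place of the change, but it does not show that the step has the same size at both places, and with one step per core it gives no rule for carrying the change to a further core.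

The compounds shown leave open how an amine or a carboxylic acid at either place would read in this assay. They also leave open whether a smaller halogen such as fluoro or chloro would follow bromo on either core.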